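A few compounds are considered here, and "the series" means these few. Any claim that something is new, unique, unknown or untested is made for them only; others in the source may bear on it.

Measured compounds:
- compound 1 `COc1ccc2ncc(S(=O)(=O)c3ccc(OC)c(Cl)c3)c(N3CCC(C)CC3)c2c1` — 21%
- compound 2 `COc1ccc2ncc(S(=O)(=O)c3ccc(OC)c(OC)c3)c(N3CCC(C)CC3)c2c1` — -3%
- compound 3 `COc1ccc2ncc(S(=O)(=O)c3ccc(Cl)c(Cl)c3)c(N3CCC(C)CC3)c2c1` — 87%

Compound 1 sits second highest of the three numbers in an assay on isolated protein for displacement of a labelled ligand from metabotropic glutamate receptor 5 (Homo sapiens), with a stated time of 60 min, tested at 1 uM; a higher number here means more inhibition at the concentration tested (going by the name of the read-out), a lower number less inhibition. Its nearest neighbour is compound 2, reached by a number 24 percentage points lower from compound 1 to compound 2 (beyond the scatter); the far end is compound 3, reached by a number 66 percentage points higher from compound 1 to compound 3 (beyond the scatter). Between the other two, a number 90 percentage points higher from compound 2 to compound 3 (beyond the scatter).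

Compound 4 `COc1ccc(S(=O)(=O)c2cnc3ccc(F)cc3c2N2CCC(C)CC2)cc1Cl` is not yet measured. Against compound 1 it carries fluoro in place of methoxy on an aromatic carbon. Among the compounds with values here, every measured step alters the aryl on the sulfonyl sulfur; none alters the shared core, so no step bears directly on this change. What the measured steps do show is that, on the sulfonyl aryl, trading methoxy for a halogen moved this assay upward, modestly from compound 2 to compound 1 and largely from compound 1 to compound 3. Going by these compounds, whether a methoxy-to-fluoro exchange on the core behaves alike is unknown, so only a small upward step is expected, a number 9 percentage points higher from compound 1 to compound 4 (within the scatter), with wide uncertainty.

Compound 4 is estimated at 30%, in a range from -5% to 65%.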

Compound 4, a percentage reported as inhibition, at one concentration (the size of the read-out at that concentration, not a potency): 82%
Compound 4: middle estimate off by 52 percentage points, on the low side; measured number outside the range, above it.
By their numbers in this assay, from the lowest: compound 2; then compound 1; then compounds 4 and 3 (each within the scatter of the next).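

The methoxy on the shared core is not a silent position: with the sulfonyl aryl held as in compound 1, a number 61 percentage points higher from compound 1 to compound 4 (beyond the scatter) in this assay. Within the data shown here, the earlier steps all lay on the sulfonyl aryl, so this is the first sign that a second site can carry a large step, comparable in printed size to a number 66 percentage points higher from compound 1 to compound 3 (beyond the scatter). No measurement on hand explains the rise at this carbon.

Open, going by these compounds, is whether the gain comes from fluoro entering or from methoxy leaving; the same carbon bearing only hydrogen, or a chloro, a nitrile or an amine, would help separate the two. Also open is whether fluoro on the core and the 3,4-dichlorophenyl on the sulfonyl sulfur would add up within a single compound, since the compounds shown never pair them.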